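Swapping the aryl ether end of compound 2

The compounds below may be only part of what the source reports. "The series", "measured", "known", "first", "only" and "open" are said of these compounds alone.

Compound 2 `COc1cccc(CNCCCNc2ccnc3cc(Oc4cccc(N(C)C)c4)ccc23)c1O` gives 9.28 in a physicochemical assay for acid dissociation, the lower of two numbers, and compound 1 `COc1cccc(CNCCCNc2ccnc3cc(-c4ccc(F)cc4)ccc23)c1O` gives 9.47, within the scatter of it. Among the measured compounds shown here, the only measured step, a number 0.19 log units lower from compound 1 to compound 2 (within the scatter), exchanged the same distal aryl group and stayed within the scatter. Compound 3 `COc1cccc(CNCCCNc2ccnc3cc(Oc4ccc(C(C)(C)C)cc4)ccc23)c1O` carries 4-(tert-butyl)phenyl in place of 3-(dimethylamino)phenyl on an oxygen on an aromatic ring. Since that earlier exchange at this position hardly moved the number, the step of a number 0.07 log units higher from compound 2 to compound 3 (within the scatter) is expected to stay within the scatter as well. Compound 3 is therefore estimated at 9.35, with a range from 9 to 9.7.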

Compound 3, acid dissociation constant: 9.28
For compound 3 the middle estimate is 0.07 log units above the measured one, within the range that was stated.
By their numbers in this assay, from the lowest: compounds 2, 3 and 1 (each within the scatter of the next).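

In this assay, the step on the oxygen reads no change at the digits printed from compound 2 to compound 3 (within the scatter), so removing the nitrogen of the 3-(dimethylamino)phenyl group and its hydrogen-bond acceptor leaves the number within the scatter. The step of a number 0.19 log units lower from compound 1 to compound 3 (within the scatter) gives a second aryl ether that stays within the scatter of the 4-fluorophenyl compound, as the first one did. No measurement here explains this flat result. From the compounds shown here alone, whether a carboxylic acid or a primary amine on this outer ring would move the number beyond the scatter remains open, as does the effect of a longer chain at this position.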